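The source may report more compounds than this note shows. Statements on the series, on what has been measured and on what is new or still open speak of the compounds shown alone.

Measured so far:
compound 1, `O=C(Nc1ccccc1)c1ccc(/N=N\c2c[nH]c3ccccc23)cc1`: 147000 nM
compound 2, `Cc1ccc(NC(=O)c2ccc(/N=N\c3c[nH]c4ccccc34)cc2)cc1`: 42400 nM

Among the compounds with values here, in a functional assay on MCF7 cells (Homo sapiens) for inhibition, read by MTT assay, with a stated time of 72 h (on this read-out lower numbers stand for stronger inhibition and higher numbers for weaker inhibition), compound 1 gives the highest of the two numbers recorded; the only step measured so far, a 3.5-fold lower number from compound 1 to compound 2 (0.54 log units; beyond the scatter), adds a single methyl group on an aromatic carbon and lowers the number by a modest but clear margin.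

Compound 3, `Cc1cccc(NC(=O)c2ccc(/N=N\c3c[nH]c4ccccc34)cc2)c1C`, is not yet measured. It differs from compound 1 by 2,3-dimethylphenyl in place of phenyl on an amide-type nitrogen. Within the data shown here, the step that bears on this change is the one from compound 1 to compound 2, since that step also puts methyl onto the same aromatic ring of the amide-bound part and was read as a 3.5-fold lower number from compound 1 to compound 2 (0.54 log units; beyond the scatter). With two methyl groups entering rather than one, a lowering of similar size, possibly somewhat larger, is expected, so compound 3 is expected to move by a 4.2-fold lower number from compound 1 to compound 3 (0.62 log units; beyond the scatter). The estimate for compound 3 in this assay is 35000 nM, with a range from 12000 nM to 100000 nM.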

Compound 3, half-maximal inhibitory concentration: 106000 nM
Estimate against measurement, compound 3: 3.0-fold (0.48 log units) below; the whole stated range lies below it.
By their numbers in this assay, from the lowest: compound 2; then compounds 3 and 1 (each within the scatter of the next).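

In this assay, 2,3-dimethylphenyl in place of phenyl on the amide-type nitrogen gives a 1.4-fold lower number from compound 1 to compound 3 (0.14 log units; within the scatter), so this replacement does not separate compound 3 from compound 1. Against the 4-methylphenyl of compound 2, the same position gives a 2.5-fold higher number from compound 2 to compound 3 (0.40 log units; beyond the scatter), so the result with 4-methylphenyl does not carry over to 2,3-dimethylphenyl, and the identity of the aromatic group on this nitrogen matters more than the mere presence of methyl. No supporting data are available to explain this difference between the two groups.

Open, on these data alone, is whether a ring carrying an amine or a carboxylic acid in place of methyl would give a number closer to that of compound 2 or to that of compound 3. Also open, as far as these compounds go, is whether ethyl or a longer chain on the ring would lower the number further than methyl does in compound 2.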